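The compounds below may be only part of what the source reports. "The series", "measured", "known", "first", "only" and "open" are said of these compounds alone.

Measured in a functional assay on HEK-293T cells (Homo sapiens) for cytotoxicity, read by MTT assay; on this read-out higher numbers stand for lower toxicity in this test and lower numbers for higher toxicity in this test:
- compound 1 `COc1ccc(-c2nc3ccccn3c2Nc2cc(OC)c(OC)c(OC)c2)cc1O`: 10000 nM
- compound 2 `COc1ccc(-c2nc3cc(C)ccn3c2Nc2cc(OC)c(OC)c(OC)c2)cc1O`: 8000 nM
- compound 3 `COc1cc(Nc2c(-c3cccc(O)c3)nc3cnccn23)cc(OC)c1OC`: 42000 nM

Compound 3, at 42000 nM, has the highest number of the three, and its distance from each of the other two lies beyond the scatter. Compound 4 `COc1cc(-c2nc3cnccn3c2Nc2cc(OC)c(OC)c(OC)c2)cc(OC)c1O` keeps the core of compound 3 but carries 4-hydroxy-3,5-dimethoxyphenyl in place of 3-hydroxyphenyl on an aromatic carbon.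

Within the data shown here, the only measured step, a 1.3-fold lower number from compound 1 to compound 2 (0.10 log units; within the scatter), is methyl in place of hydrogen on an aromatic carbon. Among the measured compounds shown here, it lies within the scatter and does not touch this group, so no measured step speaks directly to the exchange. Compound 1, at 10000 nM, and compound 2, at 8000 nM, differ from compound 3 in both core and aryl group, so they offer only a weak hint towards lower numbers. The expected change is small, a 1.7-fold lower number from compound 3 to compound 4 (0.23 log units; within the scatter), and is not expected to exceed the scatter. For compound 4 the estimated value is 25000 nM, with an expected range from 8000 nM to 70000 nM.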

Compound 4, concentration lethal to 50% of the cells: 34000 nM
The estimate for compound 4 lay 1.4-fold (0.13 log units) below the measured number; measured number inside the range.
By their numbers in this assay, from the lowest: compounds 2 and 1 (each within the scatter of the next); then compounds 4 and 3 (each within the scatter of the next).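

On the aromatic carbon next to the ring nitrogen, putting 4-hydroxy-3,5-dimethoxyphenyl in place of 3-hydroxyphenyl gives in this assay a 1.2-fold lower number from compound 3 to compound 4 (0.09 log units; within the scatter) and so does not separate the two compounds on this read-out. Among these compounds, this is the first measured step at this position, and it shows that, on the core of compound 3, an aryl group with more heavy atoms and more hydrogen-bond acceptors leaves the number within the scatter. No measurement shown here offers an explanation for this result.

On these data alone, it remains open whether an amine or a carboxylic acid on this aryl ring would move the number beyond the scatter. Among the compounds shown here, it is also open whether this exchange would give a similar step on the core of compound 1, as no single-place step links that core to compound 3.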